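Oxan-4-yl to cyclobutylmethyl on the amide-type nitrogen

The compounds below may be only part of what the source reports. "The series", "measured", "known", "first", "only" and "open" are said of these compounds alone.

Values in an in vitro ADME assay on microsomes (Rattus norvegicus) for metabolic stability; a lower number here means slower removal, a higher number faster removal of the compound
- compound 1 `O=C(CN(C(=O)c1ccc(-c2ccccn2)cc1)C1CCCOC1)Nc1cc(F)cc(F)c1` gives 2 mL.min-1.g-1
- compound 2 `O=C(CN(C(=O)c1ccc(-c2ccccn2)cc1)C1CCOCC1)Nc1cc(F)cc(F)c1` gives 0.6 mL.min-1.g-1

Compound 2, at 0.6 mL.min-1.g-1, holds the lower of the two numbers. Compound 3 `O=C(CN(CC1CCC1)C(=O)c1ccc(-c2ccccn2)cc1)Nc1cc(F)cc(F)c1` carries cyclobutylmethyl in place of oxan-4-yl on an amide-type nitrogen. Among the measured compounds shown here, only one measured step bears on this place, the modest 3.3-fold lower number from compound 1 to compound 2 (0.52 log units; beyond the scatter), and no measured compound has a ring of carbon only there. For the measured compounds named here, it therefore offers a size and no direct precedent. A step somewhat larger than that one is expected in this assay, towards a higher number. For compound 3 the estimated value is 3 mL.min-1.g-1, with an expected range of 1 mL.min-1.g-1 to 10 mL.min-1.g-1. The estimate means an expected 5.0-fold higher number from compound 2 to compound 3 (0.70 log units; beyond the scatter).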

Compound 3, intrinsic clearance in microsomes: 4.8 mL.min-1.g-1
Beside the measured number, compound 3's estimate is 1.6-fold (0.20 log units) below it, within the range that was stated.
By their numbers in this assay, from the lowest: compound 2; then compound 1; then compound 3.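

In this assay, cyclobutylmethyl, with its ring of carbon only, gives the highest number of the three at this amide-type nitrogen, with an 8.0-fold higher number from compound 2 to compound 3 (0.90 log units; beyond the scatter) and a 2.4-fold higher number from compound 1 to compound 3 (0.38 log units; beyond the scatter). This position therefore spans a wider range than the change from oxan-3-yl to oxan-4-yl alone showed, with oxan-3-yl now in the middle. No evidence on the cause accompanies these steps.

Going by these compounds, whether the step follows the ring oxygen, the four-membered ring or the link to the nitrogen stays open. Cyclohexyl or oxan-4-ylmethyl at this nitrogen would help separate these, and an amine such as piperidin-4-yl remains untested ground in these data.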